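Trading a methyl for an ethyl on the sulfonyl ring

A few compounds are considered here, and "the series" means these few. Any claim that something is new, unique, unknown or untested is made for them only; others in the source may bear on it.

Of the compounds shown here, three sharing one sulfonamide core have been measured. Compound 1 `O=S(=O)(Nc1ccc2oc(-c3ccccc3)nc2c1)c1cccc(C(F)(F)F)c1` was tested in an assay on cells for inhibition of HSP60/HSP10 (Homo sapiens), with a stated time of 60 min; on this read-out higher numbers stand for weaker inhibition and lower numbers for stronger inhibition. Compound 1 reaches only the assay limit of > 100000 nM, which is not a number. Compound 2 `Cc1cccc(S(=O)(=O)Nc2ccc3oc(-c4ccccc4)nc3c2)c1` likewise reaches only the limit of > 100000 nM. The change from compound 1 to compound 2, methyl in place of trifluoromethyl on an aromatic carbon, therefore gives a step that the two limits leave unreadable from compound 1 to compound 2. Among the compounds with values here, compound 3 `O=S(=O)(Nc1ccc(-c2nc3ccccc3o2)cc1)c1ccc(O)cc1`, built with a different arrangement, gives 78000 nM in this assay and is the only one with a number. Within the data shown here, compound 2 thus stands at the limit, together with compound 1, with compound 3 as the sole measured value.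

The new compound 4 `CCc1ccc(S(=O)(=O)Nc2ccc3oc(-c4ccccc4)nc3c2)cc1` differs from compound 2 by 4-ethylphenyl in place of 3-methylphenyl on a sulfonyl sulfur. Among the measured compounds shown here, no measured step describes this change, and the single step available, from compound 1 to compound 2, cannot be read because both of its ends sit at the limit of > 100000 nM in this assay, at which 2 of the 3 values shown sit. Starting from a limit, the step is expected to be a step that the limit leaves unreadable from compound 2 to compound 4, meaning no readable change. Compound 4 is therefore expected to give around 150000 nM, within a range from 60000 nM to 400000 nM, most likely again reported only as a limit.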

Compound 4, half-maximal inhibitory concentration: > 100000 nM
Compound 4 was reported as a limit; the forecaster's own chance of this, stated with the estimate: 75%; the middle value does not contradict the limit.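

Compound 2 and compound 4 are both reported in this assay only as limits, not as numbers, so placing 4-ethylphenyl where 3-methylphenyl stood gives no step that can be read: the limit of > 100000 nM in this assay, at which 3 of the 4 values shown sit.

The compounds shown leave open whether any group on the sulfonyl sulfur of this shared core would give a number rather than a limit in this assay.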